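A few compounds are considered here, and "the series" means these few. Any claim that something is new, unique, unknown or untested is made for them only; others in the source may bear on it.

Measured so far in a physicochemical assay for lipophilicity; a higher number here means a more lipophilic compound, a lower number a more polar compound:
- compound 1 `CCCCC1(c2ccccc2)NC(=O)NC1=O` gives 2.46
- compound 2 `CCCCC1(c2cccc(C)c2)NC(=O)NC1=O` gives 2.96

Of these two, compound 1 stands lowest at 2.46, and compound 2 is its nearest neighbour. Next in the series is compound 3 `CCCCC1(c2ccc(C)cc2)NC(=O)NC1=O`, not yet measured in this assay. Its difference from compound 1 is methyl in place of hydrogen on an aromatic carbon, para to a large group. Within the data shown here, one measured step bears on this change: a number 0.50 log units higher from compound 1 to compound 2 (beyond the scatter). That modest step is also methyl in place of hydrogen on an aromatic carbon, but at another place on the ring, so it is a guide and not a direct match. A step of similar size in the same direction, towards a higher number, is therefore expected. The expected step is a number 0.49 log units higher from compound 1 to compound 3 (beyond the scatter). For compound 3 the estimated value is 2.95, with an expected range of 2.7 to 3.2.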

Compound 3, partition coefficient: 2.96
Beside the measured number, compound 3's estimate is 0.01 log units below it; measured number inside the range.
By their numbers in this assay, from the lowest: compound 1; then compounds 2 and 3 (each within the scatter of the next).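

In this assay, among these compounds, the methyl para to a large group gives a number 0.50 log units higher from compound 1 to compound 3 (beyond the scatter) as the first reading at this position. Compound 2 at 2.96 and compound 3 at 2.96 lie within the scatter of each other, so on these numbers this assay does not tell the two ring places of the methyl apart. Nothing at hand accounts for the size of this step.

The compounds shown carry only methyl as a ring substituent, so it remains open whether a chlorine, a methoxy group or a carboxylic acid at this position would move the number in the same direction. Also open, going by these compounds, are the effect of a second methyl on the same ring and that of a shorter chain in place of the butyl chain.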